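Second Methoxy Group on the Benzamide Arm

This account rests on a few compounds, and the source may have more. Where it says the series, first, only, none or still open, it means among the compounds named here.

Three compounds sharing one core have been examined in a functional assay on GTL 16 cells for antiproliferative activity against GTL 16 cell line (Homo sapiens), read by CCK-8 assay, with a stated time of 72 h; a higher number here means a weaker inhibitor, a lower number a stronger inhibitor. Compound 1 `O=C(Nc1cccc(-c2oc3cc(-c4ccc(F)cc4)ccc3c(=O)c2O)c1)c1ccc(Cl)cc1` gives 9140 nM. Compound 2 `COc1cccc(C(=O)Nc2cccc(-c3oc4cc(-c5ccc(F)cc5)ccc4c(=O)c3O)c2)c1` gives 12500 nM, and compound 3 `Cc1cccc(C(=O)Nc2cccc(-c3oc4cc(-c5ccc(F)cc5)ccc4c(=O)c3O)c2)c1` gives 10900 nM. Among these three numbers compound 3 stands second highest, but every gap to its neighbours is small: a 1.2-fold higher number from compound 1 to compound 3 (0.08 log units; within the scatter), and a 1.1-fold lower number from compound 2 to compound 3 (0.06 log units; within the scatter). Likewise a 1.4-fold higher number from compound 1 to compound 2 (0.14 log units; within the scatter). None of the three changes on the carbonyl-bound aryl group has moved the read-out beyond the usual scatter.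

Compound 4 `COc1cc(OC)cc(C(=O)Nc2cccc(-c3oc4cc(-c5ccc(F)cc5)ccc4c(=O)c3O)c2)c1` carries the change (3,5-dimethoxyphenyl in place of 3-methylphenyl on a carbonyl carbon). Going by the values given here, the steps that bear on it are the exchange of methyl for methoxy, seen from compound 2 to compound 3, and the two exchanges of the whole aryl group starting from compound 1; all three lay within the scatter. A second methoxy on the same ring is therefore expected to produce no step beyond the scatter, with no clear direction. The estimate for compound 4 is 12000 nM, with a range from 6000 nM to 25000 nM, which corresponds to an expected step of a 1.1-fold higher number from compound 3 to compound 4 (0.04 log units; within the scatter).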

Compound 4, half-maximal inhibitory concentration: 19600 nM
Compound 4: middle estimate off by 1.6-fold (0.21 log units), on the low side; the measured number falls inside the stated range.
By their numbers in this assay, from the lowest: compounds 1, 3, 2 and 4 (each within the scatter of the next, the first and the last beyond it).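

In this assay, the aryl group on the carbonyl carbon now gives its first step beyond the scatter, though a modest one (a 2.1-fold higher number from compound 1 to compound 4 (0.33 log units; beyond the scatter)), so 3,5-dimethoxyphenyl in compound 4 reads as weaker than the 4-chlorophenyl group of compound 1, a separation that no exchange among the earlier compounds had shown. The second methoxy on its own is not resolved, however: adding it in place of hydrogen stays within the scatter (a 1.6-fold higher number from compound 2 to compound 4 (0.20 log units; within the scatter)), as does the whole exchange of 3-methylphenyl for 3,5-dimethoxyphenyl (a 1.8-fold higher number from compound 3 to compound 4 (0.25 log units; within the scatter)), so the position tolerates these groups with only the two ends of the series standing apart. Nothing available accounts for that separation between the two ends.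

The compounds shown leave open whether an amine or a carboxylic acid on this aryl ring, or a longer chain such as butoxy in place of methoxy, would move the number further in either direction. They also leave open whether any group at this place can give a clearly lower number than the 4-chlorophenyl group does.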